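Replacing fluoro with methoxy on the weakest enantiomer

A few compounds are considered here, and "the series" means these few. Any claim that something is new, unique, unknown or untested is made for them only; others in the source may bear on it.

Compound 3 `OC[C@@]1(c2cccc(F)c2)NC[C@@H](O)[C@@H]1O` is the weakest inhibitor among the three compounds measured in an assay on isolated protein for inhibition of lysosomal alpha-glucosidase (Rattus norvegicus), read by colorimetric assay (a higher number here means a weaker inhibitor, a lower number a stronger inhibitor), where compound 3 gives 216000 nM. Its mirror image, compound 1 `OC[C@]1(c2cccc(F)c2)NC[C@H](O)[C@H]1O`, gives 43000 nM, and the step of a 5.0-fold higher number from compound 1 to compound 3 (0.70 log units; beyond the scatter) is explained only by the fact that compounds 1 and 3 differ only in the configuration as drawn. Among the measured compounds shown here, compound 2 `COc1ccc([C@@]2(CO)NC[C@H](O)[C@H]2O)cc1` gives 2100 nM; no single-change step links it to compound 3, so its value stands on its own.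

Compound 4 `COc1cccc([C@]2(CO)NC[C@@H](O)[C@@H]2O)c1` differs from compound 3 by methoxy in place of fluoro on an aromatic carbon. For the measured compounds named here, none of the measured steps concerns a substituent exchange on the aromatic ring, so the only direct precedent is the stereochemical step, which does not bear on this change. Compound 2, which also carries a methoxy group, shows a much lower number than compound 3, but it differs in more than one respect, so it offers only a hint.

Compound 4 is therefore expected to be close to compound 3, with the step of a 1.8-fold lower number from compound 3 to compound 4 (0.26 log units; within the scatter) estimated as a modest drop in number at most. The estimate for compound 4 is 120000 nM, ranging from 25000 nM to 500000 nM.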

Compound 4, half-maximal inhibitory concentration: 52000 nM
Compound 4: the middle estimate sits 2.3-fold (0.36 log units) above what was measured; the measured number falls inside the stated range.
By their numbers in this assay, from the lowest: compound 2; then compounds 1 and 4 (each within the scatter of the next); then compound 3.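

In this assay, among the compounds shown here, methoxy in place of fluoro on an aromatic carbon gives a 4.2-fold lower number from compound 3 to compound 4 (0.62 log units; beyond the scatter), the first measured step that concerns a substituent on the aromatic ring rather than configuration. A single exchange at this place, with the configuration of the core unchanged, therefore moves the number by a step of the same modest grade as a 5.0-fold higher number from compound 1 to compound 3 (0.70 log units; beyond the scatter). Nothing at hand accounts for why this exchange shifts the number.

As far as these compounds go, whether the same exchange gives a step of similar size in the configuration of compound 1 remains open. Also open, from the compounds shown here alone, is how an amine or a carboxylic acid on this aromatic carbon would compare with methoxy and fluoro in this assay.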